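Estimating compound 4 from a limit

The source may hold more compounds than are shown below. What is called first, only, known or untested is meant among the compounds shown, and "the series" means these compounds.

Measured in a functional assay on MDA-MB-231 cells (Homo sapiens) for antiproliferative activity, read by luminescence, with a stated time of 24 h; on this read-out lower numbers stand for stronger inhibition and higher numbers for weaker inhibition:
- Compound 1 `Cc1cc(C)c2c(c1C)OC(C)(COc1ccc(/C=C3\SC(=O)NC3=O)cc1)CC2`: 10800 nM
- Compound 2 `CC(=O)NCCNC(=O)CCC(=O)Oc1c(C)c(C)c2c(c1C)CCC(C)(COc1ccc(/C=C3\SC(=O)NC3=O)cc1)O2`: > 25000 nM, a limit
- Compound 3 `Cc1c(C)c2c(c(C)c1OC(=O)CCC(=O)O)CCC(C)(COc1ccc(/C=C3\SC(=O)NC3=O)cc1)O2`: > 25000 nM, a limit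

Compound 3 has only a limit and no exact number. This is the limit of > 25000 nM in this assay, at which 2 of the 3 values shown sit. Compound 4 `Cc1c(C)c2c(c(C)c1OC(=O)OC(C)(C)C)CCC(C)(COc1ccc(/C=C3\SC(=O)NC3=O)cc1)O2` has not yet been measured. It carries tert-butoxy in place of 2-carboxyethyl on a carbonyl carbon, so the chain's end changes while the carbonyl stays.

Among the compounds with values here, two measured steps bear on this change. The first is an at least 2.3-fold higher number from compound 1 to compound 3 (0.36 log units; beyond the scatter), where the ((2-carboxyethyl)carbonyl)oxy group enters the core of compound 1. It shows a change beyond the scatter, although its true size is open. The second is a step that the two limits leave unreadable from compound 2 to compound 3, which also changes the far end of the chain but gives no usable size.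

Within the data shown here, compound 1 is the only measured compound with an exact number, at 10800 nM, so it serves as the best guide. Compound 2 argues for caution, since replacing the chain's end there did not yield a number. A modest move towards stronger inhibition is therefore expected, and another limit remains possible. The estimated step is an at least 1.7-fold lower number from compound 3 to compound 4 (0.25 log units; that floor lies within the scatter). For compound 4, the expected value is 14000 nM, with an estimated range of 5000 nM to 25000 nM.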

Compound 4, half-maximal inhibitory concentration: 3300 nM
For compound 4 the middle estimate is 4.2-fold (0.63 log units) above the measured one; measured number outside the range, below it.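

At this position on the core, the far end of the chain decides the outcome. In this assay, tert-butoxy in place of 2-carboxyethyl on the carbonyl carbon gives an at least 7.5-fold lower number from compound 3 to compound 4 (0.87 log units; beyond the scatter) and not merely a small shift, and tert-butoxy in place of 2-((2-acetamidoethyl)carbamoyl)ethyl gives an at least 7.5-fold lower number from compound 2 to compound 4 (0.87 log units; beyond the scatter) in the same direction. Filling this position is therefore not harmful in itself, since (tert-butoxycarbonyl)oxy in place of hydrogen gives a 3.3-fold lower number from compound 1 to compound 4 (0.51 log units; beyond the scatter) while ((2-carboxyethyl)carbonyl)oxy gives an at least 2.3-fold higher number from compound 1 to compound 3 (0.36 log units; beyond the scatter) in the opposite direction, and compound 2 goes against any gain from this position as well. Compound 2 and compound 3 each carry only a limit, so the first two steps give floors rather than full sizes: the limit of > 25000 nM in this assay, at which 2 of the 4 values shown sit.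

The compounds shown leave open whether the gain needs the branched tert-butoxy group or whether a methoxy group or a longer straight chain on the same carbonyl carbon would serve as well. They also leave open how a hydroxy group on that aromatic carbon, or an amine at the end of the chain, would compare.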